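Compound 2 to Compound 4 on DU-145 Growth

A few compounds are considered here, and "the series" means these few. Any claim that something is new, unique, unknown or untested is made for them only; others in the source may bear on it.

The three measured compounds were run in a functional assay on DU-145 cells (Homo sapiens) for inhibition, read by trypan blue exclusion, with a stated time of 96 h; on this read-out higher numbers stand for weaker inhibition of growth and lower numbers for stronger inhibition of growth. Compound 1 `O=C(/C(=C\c1ccc(O)c([N+](=O)[O-])c1)SCc1ccc(Br)cc1)c1ccc(Br)cc1` gives 10000 nM, compound 3 `O=C(/C(=C\c1ccc(F)cc1F)S(=O)(=O)c1ccc(Cl)cc1)c1ccc(Br)cc1` gives 25000 nM, and compound 2 `O=C(/C(=C\c1ccc(Br)c(O)c1)S(=O)(=O)c1ccc(Br)cc1)c1ccc(Br)cc1` gives 50000 nM. Compound 2 stands highest of the three numbers; its nearest neighbour is compound 3, whose gap lies within the scatter, while compound 1 lies furthest away, beyond the scatter. Compound 4 `Nc1c(Br)cc(Br)cc1/C=C(\C(=O)c1ccc(Br)cc1)S(=O)(=O)c1ccc(Br)cc1` has not yet been measured in this assay. Its difference from compound 2 is 2-amino-3,5-dibromophenyl in place of 4-bromo-3-hydroxyphenyl on a double-bonded chain carbon bound to a double-bonded chain carbon. For the measured compounds named here, no step between measured compounds carries this change, so the expected step of a 1.3-fold lower number from compound 2 to compound 4 (0.10 log units; within the scatter) is none beyond the scatter. Compound 4 is accordingly estimated at 40000 nM, with a range from 10000 nM to 100000 nM.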

Compound 4, concentration for 50% growth inhibition: 25000 nM
Estimate against measurement, compound 4: 1.6-fold (0.20 log units) above; measured number inside the range.
By their numbers in this assay, from the lowest: compound 1; then compounds 3, 4 and 2 (each within the scatter of the next).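

In this assay, for the compounds shown here, 2-amino-3,5-dibromophenyl in place of 4-bromo-3-hydroxyphenyl on a double-bonded chain carbon bound to a double-bonded chain carbon gives a 2.0-fold lower number from compound 2 to compound 4 (0.30 log units; within the scatter) and is the first step read at this place. The two groups therefore cannot be told apart here on growth inhibition, even though the hydroxyl gives way to an amine and the ring carries a further bromine. Nothing at hand bears on this result. Going by these compounds, whether a carboxylic acid or a methoxy group at this place would move the number beyond the scatter stays open.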